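A few compounds are considered here, and "the series" means these few. Any claim that something is new, unique, unknown or untested is made for them only; others in the source may bear on it.

Of the compounds shown here, three have so far been read in a physicochemical assay for solubility, in phosphate buffer, at pH 7.4 (on this read-out higher numbers stand for higher solubility and lower numbers for lower solubility), of the working set. Compound 1 (`C[C@@H]1CN(C(=O)OC(C)(C)C)CCN1c1ncc(OCc2ccc(S(=O)(=O)N(C)C)cc2)cn1`) gives < 5000 nM as its result, which is a limit and not a number. Compound 2 (`C[C@@H]1CN(C(=O)OC(C)(C)C)CCN1c1ncc(OCc2ccc(S(C)(=O)=O)cc2F)cn1`) gives < 5000 nM as its result, again a limit and not a number. For the measured compounds named here, compound 3 (`Cc1cc(COc2cnc(N3CCN(C(=O)OC(C)(C)C)CC3)nc2)ccn1`) gives 66000 nM and so holds the only actual number among the three. No two of these compounds differ in one place only, so no measured step is available as a guide.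

Compound 4 (`COc1cnccc1COc1cnc(N2CCN(C(=O)OC(C)(C)C)CC2)nc1`) is still to be measured. It carries 3-methoxypyridin-4-yl in place of 2-methylpyridin-4-yl on a saturated chain carbon bound to an oxygen on an aromatic ring. Going by the values given here, the only anchor is compound 3 at 66000 nM in this assay and no change beyond the usual scatter is expected. The estimated step (a 1.3-fold lower number from compound 3 to compound 4 (0.12 log units; within the scatter)) stays within that scatter. For compound 4 the expected value is 50000 nM with an estimated range from 15000 nM to 150000 nM in the coming measurement.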

Compound 4, solubility: 11000 nM
For compound 4 the middle estimate is 4.5-fold (0.66 log units) above the measured one; the whole stated range lies above it.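

For the compounds shown here, exchanging 2-methylpyridin-4-yl for 3-methoxypyridin-4-yl on a saturated chain carbon bound to an oxygen on an aromatic ring gives the only measured step in this assay, a 6.0-fold lower number from compound 3 to compound 4 (0.78 log units; beyond the scatter), which shows that this read-out responds to a change at this place. The two group names differ both in the substituent and in the numbering of its place on the ring, so this one step cannot be assigned to either difference. Compound 4 still gives a number and not a limit, so the read-out leaves some room for lower values at this place before the floor is reached: the limit of < 5000 nM in this assay, at which 2 of the 4 values shown sit.

Whether the methoxy group itself or its place on the ring accounts for the step remains open. Also open, going by these compounds, is how a pyridine ring with no substituent, or one carrying an amine or a carboxylic acid, would read at this place.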